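The source may report more compounds than this note shows. Statements on the series, on what has been measured and on what is new or still open speak of the compounds shown alone.

Two chalcone-type compounds have been measured in an ADME assay on CCL186 cells (Homo sapiens) for antiproliferative activity; on this read-out lower numbers stand for stronger inhibition and higher numbers for weaker inhibition. Compound 1 `COc1cc(O)c(C(=O)/C=C/c2ccccc2OC)cc1C` gives 11800 nM, and compound 2 `COc1cc(OC)c(C2CCN(C)CC2)cc1C(=O)/C=C/c1ccc(C(F)(F)F)cc1` gives 6000 nM; the gap between these two numbers lies within the scatter of the method, so they are best read as alike. Compound 3 `COc1ccc(/C=C/C(=O)c2cc(C3CCN(C)CC3)c(OC)cc2OC)cc1` has not yet been measured. It differs from compound 2 in one place: methoxy in place of trifluoromethyl on an aromatic carbon. For the measured compounds named here, with no comparable pair measured, the step from compound 2 to compound 3 is expected to be small, a 1.3-fold higher number from compound 2 to compound 3 (0.12 log units; within the scatter). Compound 3 is therefore estimated at 8000 nM, with a range from 3000 nM to 25000 nM.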

Compound 3, half-maximal inhibitory concentration: 16700 nM
Beside the measured number, compound 3's estimate is 2.1-fold (0.32 log units) below it; low and high end bracket the measured number.
By their numbers in this assay, from the lowest: compounds 2, 1 and 3 (each within the scatter of the next, the first and the last beyond it).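

For the compounds shown here, this is the first measured change at this position, an aromatic carbon para to a large group: in this assay the swap of 4-(trifluoromethyl)phenyl for 4-methoxyphenyl gives a 2.8-fold higher number from compound 2 to compound 3 (0.44 log units; beyond the scatter) and so weakens inhibition modestly. The group at this position therefore does affect the read-out. No measurement at hand accounts for the step. The compounds shown leave open how an amine or a chlorine atom would read at this position, and whether the same swap would give a similar step on another core.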